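Swapping one five-membered ring for another on the shared core

The compounds below may be only part of what the source reports. "The series", "measured", "known", "first", "only" and "open" are said of these compounds alone.

Measured compounds:
compound 1 `Oc1ccc(-c2cc(-c3cccc(Cl)c3)nc(-c3cccs3)c2)cc1` gives 5050 nM
compound 2 `Oc1ccc(-c2cc(-c3ccsc3)nc(-c3cccc(Cl)c3)c2)cc1` gives 5760 nM

In a functional assay on HCT-15 cells (Homo sapiens) for cytotoxicity, read by CCK-8 assay and cell counting, with a stated time of 2 days (a higher number here means a weaker inhibitor, a lower number a stronger inhibitor), compound 2 gives 5760 nM, and compound 1 gives 5050 nM; these two numbers sit within the scatter of each other. Compound 3 `Oc1ccc(-c2cc(-c3cccc(Cl)c3)nc(-c3ccco3)c2)cc1` differs from compound 2 by furan-2-yl in place of thiophen-3-yl on an aromatic carbon. Going by the values given here, the only measured step that bears on such a ring swap is a 1.1-fold higher number from compound 1 to compound 2 (0.06 log units; within the scatter), which left the number essentially unchanged. The furan-2-yl change rests on that single step alone, so no shift beyond the scatter is expected in this assay, a 1.0-fold lower number from compound 2 to compound 3 (0.02 log units; within the scatter). Compound 3 is therefore estimated at 5500 nM, within 2500 nM to 12000 nM.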

Compound 3, half-maximal inhibitory concentration: 8020 nM
Estimate against measurement, compound 3: 1.5-fold (0.16 log units) below, and the stated range covers the measured number.
By their numbers in this assay, from the lowest: compounds 1, 2 and 3 (each within the scatter of the next).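

In this assay, going by these compounds alone, the furan-2-yl group puts an oxygen-bearing ring at this place, next to the ring nitrogen, where the earlier compounds held sulfur-bearing rings, yet both new steps stay within the scatter (a 1.4-fold higher number from compound 2 to compound 3 (0.14 log units; within the scatter); a 1.6-fold higher number from compound 1 to compound 3 (0.20 log units; within the scatter)). Across these three compounds, then, the number does not separate furan-2-yl from either thiophene, and no compound can be ranked above another. Nothing measured here offers an explanation for this result. Going by these compounds, whether an amine or a carboxylic acid at this place, in place of a five-membered aromatic ring, would shift the number beyond the scatter remains open.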